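Sulfamoyl for Methoxy on the Pendant Phenyl Ring

This account rests on a few compounds, and the source may have more. Where it says the series, first, only, none or still open, it means among the compounds named here.

Compound 1 `Fc1ccc2nc(-c3cc(-c4ccccc4)nn3-c3ccccc3)ccc2c1` and compound 2 `COc1ccc(-n2nc(-c3ccccc3)cc2-c2ccc3cc(F)ccc3n2)cc1` share one core and differ only by a methoxy in place of hydrogen on an aromatic carbon. In an ADME assay on Huh-7 cells (Homo sapiens) for cytotoxicity, read by XTT assay, with a stated time of 3 days, tested at 20 uM (on this read-out higher numbers stand for a weaker effect at the one concentration tested and lower numbers for a stronger effect), compound 1 gives 126%, and compound 2 gives 116%; the step of a number 10 percentage points lower from compound 1 to compound 2 (within the scatter) shows no real separation. Among the two numbers compound 2 stands lowest, with compound 1 its nearest neighbour at a gap within the scatter. Compound 3 `NS(=O)(=O)c1ccc(-n2nc(-c3ccccc3)cc2-c2ccc3cc(F)ccc3n2)cc1` differs from compound 2 in one place: sulfamoyl in place of methoxy on an aromatic carbon, so that 4-methoxyphenyl becomes 4-sulfamoylphenyl. Among the measured compounds shown here, no measured step involves a sulfamoyl group, and the single step that is known, from compound 1 to compound 2, lay within the scatter, so the expectation for compound 3 is a change no larger than the scatter, in either direction. Compound 3 is therefore estimated at 112% in this assay, with a likely range from 90% to 135%. The expected step of a number 4 percentage points lower from compound 2 to compound 3 (within the scatter) is estimated to stay within the scatter.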

Compound 3, a percentage reported as activity, at one concentration (the size of the read-out at that concentration, not a potency): 89.2%
Compound 3: the middle estimate sits 22.8 percentage points above what was measured; measured number outside the range, below it.
By their numbers in this assay, from the lowest: compound 3; then compounds 2 and 1 (each within the scatter of the next).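

In this assay this position responds to what it carries: sulfamoyl in place of methoxy gives a number 26.8 percentage points lower from compound 2 to compound 3 (beyond the scatter) and sulfamoyl in place of hydrogen gives a number 36.8 percentage points lower from compound 1 to compound 3 (beyond the scatter), both towards a stronger effect at the one concentration tested. Methoxy in place of hydrogen had shown no such separation, so among the three groups shown only sulfamoyl moves the number beyond the scatter. No measurement at hand bears on the cause of this shift.

The compounds shown leave open whether the step needs the whole sulfamoyl group or would also appear with a methylsulfonyl group, a carboxylic acid or an amine on the same aromatic carbon. They also leave open how the effect of compound 3 changes at other concentrations.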